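The source may hold more compounds than are shown below. What is called first, only, known or untested is meant among the compounds shown, and "the series" means these compounds.

Going by the values given here, compound 1 `Clc1ccc(/C=N/Nc2nc3ccccc3nc2Cc2ccccc2)cc1` is the first of two compounds measured in an assay on isolated protein for inhibition of Amine oxidase [flavin-containing] A (Homo sapiens), read by spectrophotometry (a lower number here means a stronger inhibitor, a higher number a weaker inhibitor), where compound 1 gives 76 nM. Compound 2 `C/C(=N\Nc1nc2ccccc2nc1Cc1ccccc1)c1cccs1` differs from it by a 1.2-fold lower number from compound 1 to compound 2 (0.07 log units; within the scatter); in this assay compound 2 gives 64 nM, a number that sits within the scatter of compound 1. Compound 3 `C=NNc1nc2ccccc2nc1Cc1ccccc1` has not yet been measured. Relative to compound 2 it carries a group of 2 heavy atoms (1 carbon, 1 nitrogen; no ring) in place of a group of 8 heavy atoms (6 carbon, 1 nitrogen, 1 sulfur; one five-membered aromatic ring with 1 hetero atom), on a nitrogen on an aromatic ring. Among the compounds with values here, the one measured step, a 1.2-fold lower number from compound 1 to compound 2 (0.07 log units; within the scatter), swapped one ring-bearing group for another on that nitrogen and moved the number hardly at all; it says nothing about removing the ring altogether, which is what compound 3 does. Within the data shown here, with no measured step covering such a loss, the expectation for compound 3 is a higher number, estimated at a 9.4-fold higher number from compound 2 to compound 3 (0.97 log units; beyond the scatter). Compound 3 is therefore expected to give about 600 nM in this assay, within a range from 150 nM to 3000 nM.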

Compound 3, half-maximal inhibitory concentration: 86 nM
Compound 3: the middle estimate sits 7.0-fold (0.84 log units) above what was measured; measured number outside the range, below it.
By their numbers in this assay, from the lowest: compounds 2, 1 and 3 (each within the scatter of the next).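

In this assay, the ring on this nitrogen proves removable: replacing the five-membered aromatic ring group gives a 1.3-fold higher number from compound 2 to compound 3 (0.13 log units; within the scatter), and replacing the six-membered aromatic ring group gives a 1.1-fold higher number from compound 1 to compound 3 (0.05 log units; within the scatter). The earlier step exchanged one ring-bearing group for another, whereas these steps show that, across these three compounds, the number holds within the scatter even when the group of 2 heavy atoms with no ring takes the place of either larger group. Nothing available explains why the ring can be lost in this way.

From the compounds shown here alone, whether a longer chain, an amine or a carboxylic acid in this place would also leave the number within the scatter remains open. The compounds shown also leave open how much the number depends on the shared core, since it is the same in all three.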